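Amide to urea on the methoxy core: an untested step

The compounds below may be only part of what the source reports. "The series", "measured", "known", "first", "only" and "open" are said of these compounds alone.

Measured so far:
compound 1, `COc1cc(-c2nn(-c3cccc(NC(=O)c4ccc(Cl)c(C(F)(F)F)c4)c3)cc2-c2ccncc2)ccc1Cl`, > 32500 nM
compound 2, `O=C(Nc1cccc(-n2cc(-c3ccncc3)c(-c3ccc(Cl)c(O)c3)n2)c1)Nc1cc(C(F)(F)F)cc(C(F)(F)F)c1`, 1870 nM
compound 3, `O=C(Nc1cccc(-n2cc(-c3ccncc3)c(-c3ccc(Cl)c(O)c3)n2)c1)Nc1ccc(Cl)c(C(F)(F)F)c1`, 5730 nM

In a functional assay on HT-29 cells (Homo sapiens) for inhibition, read by sulforhodamine B assay, with a stated time of 48 h (a higher number here means a weaker inhibitor of growth, a lower number a stronger inhibitor of growth), compound 1 reaches only a limit, > 32500 nM, and no number is known for it. That limit is the limit of > 32500 nM in this assay, at which 1 of the 3 values shown sits. Compound 2 and compound 3 carry a urea rather than an amide and differ from compound 1 elsewhere as well, so their values cannot be set against it directly. Compound 4, `COc1cc(-c2nn(-c3cccc(NC(=O)Nc4ccc(Cl)c(Cl)c4)c3)cc2-c2ccncc2)ccc1Cl`, keeps the core of compound 1 and changes one place: (3,4-dichlorophenyl)amino in place of 4-chloro-3-(trifluoromethyl)phenyl on a carbonyl carbon. Compound 4 then carries a urea like compound 2 and compound 3. Where this lands is uncertain, since no pair of measured compounds shows this change alone; a downward step is thought likely, yet compound 4 might also remain at the limit. The expected step is an at least 2.1-fold lower number from compound 1 to compound 4 (0.33 log units; beyond the scatter), giving compound 4 an estimated 15000 nM, within 3000 nM to 40000 nM.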

Compound 4, concentration for total growth inhibition: 6460 nM
Compound 4: middle estimate off by 2.3-fold (0.37 log units), on the high side; the measured number falls inside the stated range.
By their numbers in this assay, from the lowest: compound 2; then compounds 3 and 4 (each within the scatter of the next). At a limit, above all of these: compound 1.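

In this assay, putting (3,4-dichlorophenyl)amino in place of 4-chloro-3-(trifluoromethyl)phenyl on the carbonyl carbon turns the amide into a urea and gives an at least 5.0-fold lower number from compound 1 to compound 4 (0.70 log units; beyond the scatter), the first sign that this position matters on this core. That size is only a minimum, because compound 1 stands at a limit and not at a number: the limit of > 32500 nM in this assay, at which 1 of the 4 values shown sits.

The change adds a nitrogen and swaps trifluoromethyl for chloro at once, and these two parts cannot be told apart here. Still open, from the compounds shown here alone, is how a urea ending in a cyclohexyl ring or a short alkyl chain would read on this core.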